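Amide group swap from compound 2 to compound 4

The source may hold more compounds than are shown below. What is called first, only, known or untested is meant among the compounds shown, and "the series" means these compounds.

Values in a physicochemical assay for lipophilicity, read by HPLC, in phosphate buffer, measured as octanol-water partition, with a stated time of 1 h, at pH 7.4 (a higher number here means a more lipophilic compound, a lower number a more polar compound), for the measured compounds
- compound 1 `N#Cc1ccc(C(=O)Nc2ccc(F)c([C@]3(C4CC4)C=C(CF)OC(N)=N3)c2)nc1` gives 2.9
- compound 2 `C[C@@]1(c2cc(NC(=O)c3ncc(C#N)cc3Cl)ccc2F)C=C(CF)OC(N)=N1` gives 2.5
- compound 3 `CC1=C[C@@](C)(c2cc(NC(=O)c3ccc(C#N)cn3)ccc2F)N=C(N)O1` gives 2.2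

Compound 2 lies within the scatter of compound 3 and beyond the scatter of compound 1, whose number is the higher of that pair. Compound 4 `C[C@@]1(c2cc(NC(=O)c3coc(C(F)F)n3)ccc2F)C=C(CF)OC(N)=N1` has not yet been measured. It carries 2-(difluoromethyl)-1,3-oxazol-4-yl in place of 3-chloro-5-cyanopyridin-2-yl on a carbonyl carbon. Among the measured compounds shown here, no pair of measured compounds differs in one place only, so the set gives no direct guide to this swap, and the range is kept wide. The expected change is a slight drop, not beyond the scatter (a number 0.20 log units lower from compound 2 to compound 4 (within the scatter)). For compound 4 the estimate is 2.3 (expected range 1.8 to 2.8).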

Compound 4, distribution coefficient: 2.6
Beside the measured number, compound 4's estimate is 0.30 log units below it, and the stated range covers the measured number.
By their numbers in this assay, from the lowest: compounds 3, 2, 4 and 1 (each within the scatter of the next, the first and the last beyond it).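

Among the compounds shown here, on the carbonyl carbon, in this assay the swap of 3-chloro-5-cyanopyridin-2-yl for 2-(difluoromethyl)-1,3-oxazol-4-yl gives a number 0.10 log units higher from compound 2 to compound 4 (within the scatter) as the first single-place step. At this place, a five-membered aromatic ring with 2 hetero atoms and a six-membered aromatic ring with 1 hetero atom therefore give numbers that cannot be told apart. Nothing measured here accounts for this result.

Which part of either group sets the number stays open. So does the reading in this assay with trifluoromethyl or an amine in place of difluoromethyl on the oxazole ring.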